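The compounds below may be only part of what the source reports. "The series", "measured", "known", "first", "only" and "open" are said of these compounds alone.

In a functional assay on EOL1 cells (Homo sapiens) for inhibition, read by fluorescence, with a stated time of 72 h (on this read-out higher numbers stand for weaker inhibition of growth and lower numbers for stronger inhibition of growth), compound 1 (`CCCCn1cnc2c(NCc3cccc(Cl)c3)nc(N[C@H]3CC[C@H](N)CC3)nc21`) gives 350 nM, compound 2 (`CC(C)CCn1cnc2c(NCc3cccc(Cl)c3)nc(N[C@H]3CC[C@H](N)CC3)nc21`) gives 1330 nM and compound 3 (`CCCCCCn1cnc2c(Nc3cccc(Cl)c3)nc(N[C@H]3CC[C@H](N)CC3)nc21`) gives 310 nM. Compound 2 therefore has the highest number of the three, and both of the other values lie beyond the scatter from it. Compound 4 (`CC(C)CCn1cnc2c(Nc3ccc(O)cc3)nc(N[C@H]3CC[C@H](N)CC3)nc21`) keeps the chain of compound 2 but carries 4-hydroxyphenyl in place of 3-chlorobenzyl on a nitrogen on an aromatic ring.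

Among the compounds with values here, the only measured step, a 3.8-fold higher number from compound 1 to compound 2 (0.58 log units; beyond the scatter), is modest and concerns the chain, which stays the same here, so it does not measure this change. Compound 3, at 310 nM, is the closest guide, since it too has no benzyl carbon on that nitrogen. However, it differs from compound 4 in its chain and its ring substituent, and no measured compound carries the 4-hydroxyphenyl group. On this thin evidence, a moderately lower number is expected in this assay, with considerable uncertainty. The expected change is a 3.3-fold lower number from compound 2 to compound 4 (0.52 log units; beyond the scatter), which is only an estimate. For compound 4 the estimated value is 400 nM, with an expected range from 70 nM to 2000 nM.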

Compound 4, concentration for 50% growth inhibition: 30 nM
Beside the measured number, compound 4's estimate is 13-fold (1.12 log units) above it; measured number below the stated range.
By their numbers in this assay, from the lowest: compound 4; then compounds 3 and 1 (each within the scatter of the next); then compound 2.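

On a nitrogen on an aromatic ring, the group turns out to matter a great deal in this assay: replacing 3-chlorobenzyl with 4-hydroxyphenyl gives a 44-fold lower number from compound 2 to compound 4 (1.65 log units; beyond the scatter), a far larger step than the only one available before, the chain change of a 3.8-fold higher number from compound 1 to compound 2 (0.58 log units; beyond the scatter). This single swap nevertheless alters several things at once, since the chlorine and the benzyl carbon leave while a hydroxyl, counted as 1 hydrogen-bond donor and 1 hydrogen-bond acceptor, enters, so the step shows the effect of the whole exchange of (3-chlorobenzyl)amino for (4-hydroxyphenyl)amino and not the share of any one part. No measurement offered here explains why this exchange has so large an effect.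

The compounds shown leave open how much of the step belongs to the hydroxyl and how much to the loss of the benzyl carbon or the chlorine, a question that an unsubstituted phenyl or an unsubstituted benzyl group on the same nitrogen would help to separate. They also leave open whether a methoxy group or an amine could take the place of the hydroxyl on the phenyl ring, and whether the step would be the same size with a different chain.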